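The source may report more compounds than this note shows. Statements on the series, on what has been measured and on what is new or still open speak of the compounds shown alone.

The compounds here share one core. Compound 1 `CCOC(=O)c1cccc(-c2ccc(C)cc2)c1` gives 140000 nM in an assay on COS-7 cells for inhibition of patatin-like phospholipase domain-containing protein 2 (Mus musculus); on this read-out higher numbers stand for weaker inhibition and lower numbers for stronger inhibition. Compound 2 `CCOc1ccc(-c2cccc(C(=O)O)c2)cc1` reaches only a limit of the assay, > 200000 nM in this assay. Compound 3 `CCCCCCOC(=O)c1cccc(-c2ccc(OCC)cc2)c1` likewise stops at a limit, > 200000 nM in this assay. The step that the two limits leave unreadable from compound 2 to compound 3 therefore cannot be read, since both of its ends sit at the limit of > 200000 nM in this assay, at which 2 of the 3 values shown sit. Among the values shown, compound 2 thus stands as a limit rather than a number, and nothing in the data says how far it lies from compound 1.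

Compound 4 `CCOc1ccc(-c2cccc(NC(=O)N(C)C)c2)cc1` differs from compound 2 by (dimethylcarbamoyl)amino in place of carboxy on an aromatic carbon. For the measured compounds named here, no measured step bears on this change: the one step recorded, a step that the two limits leave unreadable from compound 2 to compound 3, is unreadable, and compound 1 differs from compound 2 in two places at once. The estimate therefore rests only on compound 1, whose 140000 nM shows that a member of this series can give a number in this assay. Compound 4 is expected at 150000 nM, within a range from 40000 nM to 500000 nM. That expectation corresponds to a step of an at least 1.3-fold lower number from compound 2 to compound 4 (0.12 log units; that floor lies within the scatter), which may still end at a limit.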

Compound 4, half-maximal inhibitory concentration: 70000 nM
Compound 4: the middle estimate sits 2.1-fold (0.33 log units) above what was measured, and the stated range covers the measured number.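

In this assay, (dimethylcarbamoyl)amino in place of carboxy on this aromatic carbon gives the only step shown that can be read: an at least 2.8-fold lower number from compound 2 to compound 4 (0.45 log units; beyond the scatter). Compound 2 gives > 200000 nM, which is a limit of the assay and not a number, so only a floor on the size of this step is known. For the compounds shown here, the step from compound 2 to compound 3 cannot be read, so this change is the first sign that the number responds to a change, and the two groups match in their counts of hydrogen-bond donors and acceptors while differing in heavy atoms.

The compounds shown leave open whether a plain amine on the same aromatic carbon would lower the number as well. They also leave open whether longer chains in place of the two methyl groups on the nitrogen would do so.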